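The source may report more compounds than this note shows. Statements on the series, on what has been measured and on what is new or still open speak of the compounds shown alone.

Compound 1 `COc1ccccc1NC(=O)c1c(NCCO)cc(-c2cccc(Br)c2)oc1=O` in an ADME assay on Huh-7 cells (Homo sapiens) for cytotoxicity, with a stated time of 3 days (a lower number here means that less compound is tolerated, a higher number that more compound is tolerated), gives > 20000 nM, which is a limit of the assay.
Compound 2 `O=C(Nc1ccc(Cl)cc1)c1c(NCCO)cc(-c2ccc(Br)cc2)oc1=O` in this assay gives > 20000 nM, also a limit.
Compound 3 `COc1ccccc1NC(=O)c1c(NCCO)cc(-c2ccc(Br)cc2)oc1=O` in this assay gives > 20000 nM, again a limit.

Going by the values given here, compound 3 thus stands where every measured compound stands: all three values sit at the same limit, (the limit of > 20000 nM in this assay, at which 3 of the 3 values shown sit), and no compound can be ranked against another. Compound 4 `COc1ccc(NC(=O)c2c(NCCO)cc(-c3ccc(Br)cc3)oc2=O)cc1` differs from compound 3 in one respect: 4-methoxyphenyl in place of 2-methoxyphenyl on an amide-type nitrogen. Two measured steps lead into compound 3, a step that the two limits leave unreadable from compound 1 to compound 3 and a step that the two limits leave unreadable from compound 2 to compound 3; both have limits at each end, so their size stays hidden, and neither concerns an exchange of one methoxyphenyl for another. Among the compounds with values here, no measured step in this set shows any movement in this assay beyond the scatter. The expected step is accordingly no readable change, a step that the limit leaves unreadable from compound 3 to compound 4. Compound 4 is estimated at 30000 nM, with a range from 12000 nM to 80000 nM, and is most likely to be reported again only as a limit.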

Compound 4, half-maximal cytotoxic concentration: > 20000 nM
Compound 4: no number, only a limit; the forecaster's own chance of this, stated with the estimate: 85%; the middle value does not contradict the limit.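

Neither the step from compound 3 to compound 4 nor the step from compound 2 to compound 4 can be read in this assay, as both ends are limits: the limit of > 20000 nM in this assay, at which 4 of the 4 values shown sit.

The compounds shown leave open how far any of them lies from that limit, and whether 2-methoxyphenyl and 4-methoxyphenyl differ at all in this assay.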